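The compounds below may be only part of what the source reports. "The series", "measured", "known", "first", "only" and "open" are said of these compounds alone.

Compound 1 `Cc1ccc(S(=O)(=O)N2CC(c3ccc(Br)cc3)NC2=O)cc1`: > 253000 nM
Compound 2 `Cc1ccc(C2CN(S(=O)(=O)c3ccc(Cl)cc3)C(=O)N2)cc1`: 158000 nM

Both entries come from a functional assay on A549 cells (Homo sapiens) for cytotoxicity; on this read-out higher numbers stand for weaker inhibition and lower numbers for stronger inhibition. Compound 1 reads > 253000 nM, and this entry is a limit of the assay, not a number. Within the data shown here, compound 2 gives 158000 nM, the only actual number so far, which makes it the one firm reference point.

Compound 3 `Cc1ccc(C2CN(S(=O)(=O)c3ccc(C)cc3)C(=O)N2)cc1` has not yet been measured. It differs from compound 2 in a single place: methyl in place of chloro on an aromatic carbon. Methyl takes the place of chloro on an aromatic carbon, turning a 4-chlorophenyl into a 4-methylphenyl.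

Among the measured compounds shown here, no measured pair shows what this swap does in this assay, so the expectation rests on compound 2 alone, at 158000 nM. No change beyond the usual scatter is expected, in either direction. The expected step of a 1.3-fold higher number from compound 2 to compound 3 (0.10 log units; within the scatter) is accordingly small. A result reported only as a limit also remains possible. For compound 3 the estimated value is 200000 nM, with an expected range from 100000 nM to 400000 nM.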

Compound 3, half-maximal inhibitory concentration: > 302000 nM
Compound 3: a limit, no number; the forecaster's own chance of this, stated with the estimate: 35%; middle value at least 1.5-fold (0.17 log units) away from the limit.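

Compound 3 reads as a limit in this assay, not as a number: the limit of > 302000 nM in this assay, at which 1 of the 3 values shown sits.

Turning the 4-chlorophenyl into a 4-methylphenyl gives an at least 1.9-fold higher number from compound 2 to compound 3 (0.28 log units; that floor lies within the scatter), the first reading of any change at this place on the ring, and it shows no sign of stronger inhibition with methyl in place of chloro. Only a floor for this step is known, and that floor does not by itself separate the two compounds beyond the usual variation between repeated measurements, while the step linking compound 1 and compound 3 cannot be read, with a limit on both sides.

Among these compounds, compound 2 remains the only compound here with an actual number, so the true size of the swap from chloro to methyl stays open, and no measured value yet ranks the groups at this place. Also open, going by these compounds, is whether an amine, a carboxylic acid or a methoxy group at the same place on the ring would bring the number down, or leave it in the same high range.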